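Ester to Amide at the Benzyl End of Compound 1

The compounds below may be only part of what the source reports. "The series", "measured", "known", "first", "only" and "open" are said of these compounds alone.

Compound 1 `COc1ccc(COC(=O)[C@H](CSCC2CCCCC2)NC(=O)[C@@H]2CSCN2C(=O)OC(C)(C)C)cc1` gives 390 nM in an assay on IMR-32 cells for inhibition of Voltage-dependent N-type calcium channel subunit alpha-1B (Homo sapiens); a lower number here means a stronger inhibitor, a higher number a weaker inhibitor.
Compound 2 `COc1ccc(COC(=O)[C@H](CSCC2CCCCC2)NC(=O)[C@@H]2CSCN2)cc1` gives 2700 nM in this assay.
Compound 3 `COc1ccc(COC(=O)[C@H](CSCC2CCCCC2)NC(=O)[C@@H]2CCCN2C(=O)OC(C)(C)C)cc1` gives 880 nM in this assay.

Compound 1 stands lowest of the three numbers: its nearest neighbour is compound 3, with a 2.3-fold higher number from compound 1 to compound 3 (0.35 log units; beyond the scatter), and the furthest is compound 2, with a 6.9-fold higher number from compound 1 to compound 2 (0.84 log units; beyond the scatter). Compound 4 `CC(C)(C)OC(=O)N1CSC[C@H]1C(=O)N[C@@H](CSCC1CCCCC1)C(=O)NCc1ccc(O)cc1` differs from compound 1 by (4-hydroxybenzyl)amino in place of (4-methoxybenzyl)oxy on a carbonyl carbon. Neither measured step touches this end of the molecule; both concern the ring on the other carbonyl carbon and its tert-butoxycarbonyl group, so nothing measured here bears on the change. The step of a 1.5-fold higher number from compound 1 to compound 4 (0.19 log units; within the scatter) is therefore expected to be small, with no clear direction and a wide range of doubt. Compound 4 is estimated at 600 nM, between 150 nM and 2500 nM.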

Compound 4, half-maximal inhibitory concentration: 1800 nM
Estimate against measurement, compound 4: 3.0-fold (0.48 log units) below, and the stated range covers the measured number.
By their numbers in this assay, from the lowest: compound 1; then compound 3; then compounds 4 and 2 (each within the scatter of the next).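

Among the compounds shown here, the benzyl end of the molecule is not silent in this assay: (4-hydroxybenzyl)amino in place of (4-methoxybenzyl)oxy on this carbonyl carbon gives a 4.6-fold higher number from compound 1 to compound 4 (0.66 log units; beyond the scatter) and so moves the number beyond the scatter, which the earlier steps at the ring end could not show. The step joins two differences, the ester becoming an amide and the methoxy becoming a hydroxy, and it reads only as their sum. No measurement given here explains the rise.

Which of the two differences carries the step stays open, since (4-methoxybenzyl)amino and (4-hydroxybenzyl)oxy are not among the compounds shown. As far as these compounds go, how a carboxylic acid or a longer chain on this carbonyl carbon would read also stays open.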